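The source may hold more compounds than are shown below. What is called first, only, known or untested is meant among the compounds shown, and "the series" means these compounds.

Three compounds sharing one core were tested in a functional assay on Hep 3B2 cells (Homo sapiens) for antiproliferative activity, read by MTT assay, with a stated time of 24 h, tested at 1.23 ug/mL; a higher number here means a stronger effect of the compound at the concentration tested, a lower number a weaker effect. Compound 1 `Cc1ccc2nc(C(=O)Nc3c(F)cc(-c4cccc(F)c4)cc3F)c(C)c(O)c2c1` gives 11.2% in this assay. Compound 2 `Cc1c(C(=O)Nc2c(F)cc(-c3cccc(F)c3)cc2F)nc2ccc(F)cc2c1O` gives 15.3%. Compound 3 `Cc1ccc2nc(C(=O)Nc3c(F)cc(-c4cccc(F)c4)cc3F)c(C)c(C(=O)O)c2c1` gives 21.3%, the highest of the three numbers: its gap to compound 2 lies within the scatter, while the step of a number 10.1 percentage points higher from compound 1 to compound 3 (beyond the scatter) lies beyond it, a modest rise.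

Compound 4 `Cc1c(C(=O)Nc2c(F)cc(-c3cccc(F)c3)cc2F)nc2ccc(F)cc2c1C(=O)O` has not yet been measured. It differs from compound 3 in one place: fluoro in place of methyl on an aromatic carbon. The same exchange has been made once before in this set, and that step, a number 4.1 percentage points higher from compound 1 to compound 2 (within the scatter), stayed within the scatter. Among the compounds with values here, no other measured pair bears on the new step. The expectation is therefore a change that stays within the scatter, with at most a slight lean upward.

Compound 4 is expected to give 24% in this assay, with a range from 12% to 36%, which means an estimated step of a number 2.7 percentage points higher from compound 3 to compound 4 (within the scatter).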

Compound 4, a percentage reported as inhibition, at one concentration (the size of the read-out at that concentration, not a potency): 2.45%
For compound 4 the middle estimate is 21.6 percentage points above the measured one; measured number outside the range, below it.
By their numbers in this assay, from the lowest: compounds 4, 1, 2 and 3 (each within the scatter of the next, the first and the last beyond it).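

With carboxy on the core, fluoro in place of methyl on this aromatic carbon brings a number 18.9 percentage points lower from compound 3 to compound 4 (beyond the scatter) and so does far more than the hydroxy pair suggested. The exchange therefore has no fixed effect in this assay, and its outcome depends on the other group on the core: the same change on two cores in this assay, a number 4.1 percentage points higher (within the scatter) from compound 1 to compound 2 and a number 18.9 percentage points lower (beyond the scatter) from compound 3 to compound 4, 23 percentage points apart, beyond the scatter of two such steps. Carboxy in place of hydroxy also changes direction once fluoro is present, with a number 12.9 percentage points lower from compound 2 to compound 4 (beyond the scatter), so neither change can be read alone: the same change on two cores in this assay, a number 10.1 percentage points higher (beyond the scatter) from compound 1 to compound 3 and a number 12.9 percentage points lower (beyond the scatter) from compound 2 to compound 4, 23 percentage points apart, beyond the scatter of two such steps.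

The compounds shown leave open whether chloro or methoxy on this aromatic carbon would behave like fluoro or like methyl. They also leave open whether an ester or a primary amide in place of the carboxy group would show the same dependence on that neighbouring substituent.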